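Swapping the aryl group in a tetrazolyl amide series

The compounds below may be only part of what the source reports. "The series", "measured", "known", "first", "only" and "open" are said of these compounds alone.

Compound 1 `COc1cc(C(=O)Nc2nn[nH]n2)nc(-c2cccc(Cl)c2)c1` was tested in a functional assay on the whole organism with Rattus norvegicus as the target, at a dose of 3 mg/kg by the oral route (a higher number here means a stronger effect of the compound at the dose given, a lower number a weaker effect), where compound 1 gives 34%. Its companion compound 2 `CCCCc1ccc(-c2cc(OC)cc(C(=O)Nc3nn[nH]n3)n2)cc1` gives 61% in this assay, so compound 1 stands lowest of the two numbers measured, with compound 2 higher by a margin beyond the usual scatter. Compound 3 `COc1cc(C(=O)Nc2nn[nH]n2)nc(-c2ccc(C)c(C)c2)c1` has not been measured. It differs from compound 1 in one place: 3,4-dimethylphenyl in place of 3-chlorophenyl on an aromatic carbon. The aryl group attached on an aromatic carbon of the shared core is exchanged while the rest is kept. Compound 2, which carries a larger aryl group and gives 61%, suggests that room exists for a higher number at this position, so a modest upward step is expected, a number 11 percentage points higher from compound 1 to compound 3 (beyond the scatter), though it may stay within the scatter. Compound 3 is estimated at 45%, with a likely range from 25% to 65%.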

Compound 3, a percentage reported as inhibition, in the whole organism at one dose (the size of the read-out at that dose, not a potency): 82%
For compound 3 the middle estimate is 37 percentage points below the measured one, and the stated range ends below it.
By their numbers in this assay, from the lowest: compound 1; then compound 2; then compound 3.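

In this assay, the aryl group on the shared core proves a strong lever: 3,4-dimethylphenyl in place of 3-chlorophenyl gives a number 48 percentage points higher from compound 1 to compound 3 (beyond the scatter), although both groups are a six-membered aromatic ring of carbon only, with no hydrogen-bond donors or acceptors and no net charge. The top number no longer belongs to the aryl group of compound 2 at 61%, since compound 3 reaches 82%, so what is on the phenyl ring matters here, not just the presence of a larger group. Nothing measured here explains why this swap has such an effect.

As far as these compounds go, it remains open whether a single methyl group on the phenyl ring would do as well as the pair. From the compounds shown here alone, how an amine or a carboxylic acid at this position would behave also remains open.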